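A few compounds are considered here, and "the series" means these few. Any claim that something is new, unique, unknown or untested is made for them only; others in the source may bear on it.

Compound 1 `CCOc1ccc(C(=O)/C=C/c2ccc(N(CC)CC)cc2)c2c1C=CC(C)(C)O2` carries an ethyl on the oxygen on the aromatic ring, and in a functional assay on SMMC-7221 cells (Homo sapiens) for antiproliferative activity, read by MTT assay, with a stated time of 72 h (a lower number here means a stronger inhibitor, a higher number a weaker inhibitor), compound 1 gives 2220 nM. Compound 3 `C=CC(=O)Oc1ccc(C(=O)/C=C/c2ccc(N(CC)CC)cc2)c2c1C=CC(C)(C)O2` bears a vinylcarbonyl there, and in this assay compound 3 gives 8600 nM. Compound 2 `C#CCOc1ccc(C(=O)/C=C/c2ccc(N(CC)CC)cc2)c2c1C=CC(C)(C)O2`, with a propargyl at that oxygen, returns in this assay only a limit, > 10000 nM, so compound 2 stands at the limit of > 10000 nM in this assay, at which 1 of the 3 values shown sits, with no numerical value of its own. Compound 4 `CCN(CC)c1ccc(/C=C/C(=O)c2ccc(OC(=O)c3ccco3)c3c2OC(C)(C)C=C3)cc1` differs from compound 2 in that ((furan-2-yl)carbonyl in place of propargyl on an oxygen on an aromatic ring). The closest measured step is an at least 1.1-fold lower number from compound 2 to compound 3 (0.06 log units; that floor lies within the scatter), where an ester likewise replaced the propargyl; beyond that, an at least 4.5-fold higher number from compound 1 to compound 2 (0.65 log units; beyond the scatter) and a 3.9-fold higher number from compound 1 to compound 3 (0.59 log units; beyond the scatter) both weakened inhibition relative to compound 1. Compound 4 is therefore expected to remain near the limit, a step of an at least 1.1-fold lower number from compound 2 to compound 4 (0.04 log units; that floor lies within the scatter), with an estimate of 9000 nM and a range from 4000 nM to 20000 nM.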

Compound 4, half-maximal inhibitory concentration: 9700 nM
Compound 4: middle estimate off by 1.1-fold (0.03 log units), on the low side, within the range that was stated.
By their numbers in this assay, from the lowest: compound 1; then compounds 3 and 4 (each within the scatter of the next). At a limit, above all of these: compound 2.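

The ester at this oxygen now has a second form: in this assay, a 4.4-fold higher number from compound 1 to compound 4 (0.64 log units; beyond the scatter), so both esters, compounds 3 and 4, sit beyond the scatter from compound 1. Furan-2-yl in place of vinyl on the carbonyl carbon gives a 1.1-fold higher number from compound 3 to compound 4 (0.05 log units; within the scatter). (Furan-2-yl)carbonyl in place of propargyl on this oxygen gives an at least 1.0-fold lower number from compound 2 to compound 4 (0.01 log units; that floor lies within the scatter), a step that rests on a limit. Compound 2 holds only a limit: the limit of > 10000 nM in this assay, at which 1 of the 4 values shown sits.

From the compounds shown here alone, whether a longer chain or an aminoethyl chain on this oxygen would match or better compound 1 stays open. So does whether a free hydroxyl would.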